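Difluorophenyl analogue of a trimethoxyphenyl pyrazolyl chalcone

A few compounds are considered here, and "the series" means these few. Any claim that something is new, unique, unknown or untested is made for them only; others in the source may bear on it.

Three chalcones sharing one core have been measured in a functional assay on UO-31 cells (Homo sapiens) for cytotoxicity, read by sulforhodamine B assay, with a stated time of 48 h, tested at 0.01 uM; on this read-out higher numbers stand for a weaker effect at the one concentration tested and lower numbers for a stronger effect. Compound 1 `COc1cc(-c2cc(/C=C/C(=O)c3ccc(N)cc3)[nH]n2)cc(OC)c1OC` gives 91%, compound 2 `COc1cc(-c2cc(/C=C/C(=O)c3ccc(Cl)c(Cl)c3)[nH]n2)cc(OC)c1OC` gives 85%, and compound 3 `COc1ccc(C(=O)/C=C/c2cc(-c3cc(OC)c(OC)c(OC)c3)n[nH]2)cc1` gives 87%. Compound 3 stands second highest of the three, with compound 2 nearest and compound 1 furthest, every gap inside the scatter. Compound 4 `COc1cc(-c2cc(/C=C/C(=O)c3ccc(F)c(F)c3)[nH]n2)cc(OC)c1OC` differs from compound 3 by 3,4-difluorophenyl in place of 4-methoxyphenyl on a carbonyl carbon. The step of a number 2 percentage points higher from compound 2 to compound 3 (within the scatter) exchanged the same position and was flat, as was a number 6 percentage points lower from compound 1 to compound 2 (within the scatter). A swap of one phenyl group for another on the carbonyl carbon has therefore produced no shift beyond the scatter so far, and no step is expected in this assay for compound 4 either, so a number 1 percentage points lower from compound 3 to compound 4 (within the scatter) is the estimated step. Compound 4 is estimated at 86%, between 77% and 95%.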

Compound 4, a percentage reported as activity, at one concentration (the size of the read-out at that concentration, not a potency): 90%
The estimate for compound 4 lay 4 percentage points below the measured number; the measured number falls inside the stated range.
By their numbers in this assay, from the lowest: compounds 2, 3, 4 and 1 (each within the scatter of the next).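

With 3,4-difluorophenyl on a carbonyl carbon, this assay shows a number 3 percentage points higher from compound 3 to compound 4 (within the scatter) and a number 5 percentage points higher from compound 2 to compound 4 (within the scatter) and also a number 1 percentage points lower from compound 1 to compound 4 (within the scatter) in this series. All four phenyl groups at this position, whether carrying amino, methoxy, chlorine or fluorine, therefore remain within the scatter of one another at the one concentration tested. Nothing available explains this flat result.

On these data alone, whether a carboxylic acid or a morpholine on the carbonyl carbon in place of these phenyl groups would give a step beyond the scatter remains open. Also open, as far as these compounds go, is whether these four compounds stay this close at other concentrations.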